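From Pyrrolidin-1-yl to Piperidin-1-yl at the Assay Limit

The source may hold more compounds than are shown below. What is called first, only, known or untested is meant among the compounds shown, and "the series" means these compounds.

In a functional assay on DU-145 cells (Homo sapiens) for inhibition, read by MTT assay, with stated times of 18 h and 4 h (on this read-out lower numbers stand for stronger inhibition and higher numbers for weaker inhibition), compound 3 `CCCCCCOP(=O)(O)OCCSC(=S)N1CCCC1` gives > 100000 nM as its result, which is a limit of the assay and not a number. Compound 1 `CCCOP(=O)(O)OCCSC(=S)N1CCCCC1`, which carries piperidin-1-yl, reads > 100000 nM here, and this too is a limit. Compound 2 `CCCCCCCCOP(=O)(O)OCCSC(=S)N1CCCCC1`, also with piperidin-1-yl, reads > 100000 nM here, again a limit. Compound 3 therefore has no exact position among its neighbours, and all three share the same boundary: the limit of > 100000 nM in this assay, at which 3 of the 3 values shown sit, is the whole of the evidence so far.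

The move to compound 4 `CCCCCCOP(=O)(O)OCCSC(=S)N1CCCCC1` places piperidin-1-yl in place of pyrrolidin-1-yl on a thiocarbonyl carbon, as counted here: piperidin-1-yl in place of pyrrolidin-1-yl on a thiocarbonyl carbon and the rest of the molecule stays the same. Going by the values given here, no measured step makes this ring exchange. Among the compounds with values here, the only measured step is a step that the two limits leave unreadable from compound 1 to compound 2 and it alters the chain, so it gives no size to carry over. With every result in this assay at the limit, no step beyond the usual scatter is expected, in either direction. The expected change is a number no higher from compound 3 to compound 4 (the limit leaves the size open) in this estimate, and a reported limit is the likeliest outcome. Compound 4 is expected at 100000 nM with an estimated range from 40000 nM to 200000 nM in this assay.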

Compound 4, half-maximal inhibitory concentration: > 100000 nM
Compound 4 gave a limit, no number; the forecaster's own chance of this, stated with the estimate: 85%; the middle value lies on the limit itself.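

Compound 4 reads at the same limit as compound 1, compound 2 and compound 3, so no step among these four compounds can be read, whether for the ring exchange or for the chain: the limit of > 100000 nM in this assay, at which 4 of the 4 values shown sit.

In this assay the compounds shown leave open how strongly each one inhibits, and whether changing the ring or the chain makes any difference.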